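A few compounds are considered here, and "the series" means these few. Any claim that something is new, unique, unknown or untested is made for them only; others in the source may bear on it.

In a functional assay on U-87MG ATCC cells (Homo sapiens) for inhibition (a higher number here means a weaker inhibitor, a lower number a stronger inhibitor), compound 1 (`COc1cc(/C=C/C(=O)c2cccc(NC(=O)c3cc(Cl)cc(Cl)c3)c2)ccc1O`) gives > 50 ug/mL as a limit and not a number. Compound 2 (`COc1cc(/C=C/C(=O)c2cccc(NC(=O)c3ccc(Cl)cc3Cl)c2)ccc1O`) gives > 50 ug/mL as a limit as well. Compound 2 therefore has no numerical place of its own, and the whole measured picture is the limit of > 50 ug/mL in this assay, at which 2 of the 2 values shown sit, and nothing finer. Going by the values given here, the one measured step, a step that the two limits leave unreadable from compound 1 to compound 2 in size, offers no magnitude to carry forward.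

Compound 3 (`COc1cc(/C=C/C(=O)c2cccc(NC(=O)C(C)C)c2)ccc1O`) keeps the shared core but carries isopropyl in place of 2,4-dichlorophenyl on a carbonyl carbon, a difference counted as isopropyl in place of 2,4-dichlorophenyl on a carbonyl carbon in full. Among the compounds with values here, no measured step covers a change of this kind, so the data supply neither a size nor a direction for it in this assay here. With compound 2 at > 50 ug/mL as its limit and no readable step, the expectation stays close to that limit, and a further report of a limit is the likeliest outcome. The expected change is a number no higher from compound 2 to compound 3 (the limit leaves the size open) by this estimate and remains uncertain. For compound 3 the estimated value is 50 ug/mL within an expected range from 20 ug/mL to 100 ug/mL in this estimate.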

Compound 3, half-maximal inhibitory concentration: 8.31 ug/mL
The estimate for compound 3 lay 6.0-fold (0.78 log units) above the measured number; measured number outside the range, below it.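

In this assay, the group on the carbonyl carbon that also bears the amide-type nitrogen proves able to move the result out of the unreadable range: isopropyl in place of 2,4-dichlorophenyl gives an at least 6.0-fold lower number from compound 2 to compound 3 (0.77 log units; beyond the scatter), and isopropyl in place of 3,5-dichlorophenyl gives an at least 6.0-fold lower number from compound 1 to compound 3 (0.77 log units; beyond the scatter). As far as these compounds go, compound 3 thus shows that the shared core can give a measurable number in this assay when isopropyl stands at this place, and both steps set only a lower bound, so the full size of the change remains unknown. Compound 1 and compound 2 remain limits and not numbers, so the two dichlorophenyl groups cannot be ranked against each other: the limit of > 50 ug/mL in this assay, at which 2 of the 3 values shown sit.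

The compounds shown do not separate the loss of the aromatic ring from the loss of the two chlorines or from the drop in heavy atoms, as the single change removes all of these together. They also leave open how an unsubstituted phenyl, a longer chain such as n-butyl, or an amine at this place would read in this assay.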